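The source may hold more compounds than are shown below. What is called first, only, known or untested is meant among the compounds shown, and "the series" means these compounds.

Compound 2 `O=[N+]([O-])c1cccc(-c2csc(NS(=O)(=O)c3ccccc3)n2)c1` gives 200 nM in an assay on isolated protein for inhibition of kynurenine 3-monooxygenase (Rattus norvegicus) (on this read-out higher numbers stand for weaker inhibition and lower numbers for stronger inhibition), the higher of the two numbers measured, while compound 1 `Cc1ccc(S(=O)(=O)Nc2nc(-c3cccc([N+](=O)[O-])c3)cs2)cc1` gives 48 nM. Compound 3 `CC(C)c1ccc(S(=O)(=O)Nc2nc(-c3cccc([N+](=O)[O-])c3)cs2)cc1` carries isopropyl in place of hydrogen on an aromatic carbon. Among the measured compounds shown here, the one step that bears on this change is a 4.2-fold higher number from compound 1 to compound 2 (0.62 log units; beyond the scatter), which shows that removing a methyl from that carbon raises the number; a larger alkyl group put back in the same place is therefore expected to lower it, giving an expected 5.0-fold lower number from compound 2 to compound 3 (0.70 log units; beyond the scatter). On that basis compound 3 is estimated at 40 nM, within a range from 15 nM to 120 nM.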

Compound 3, half-maximal inhibitory concentration: 990 nM
For compound 3 the middle estimate is 25-fold (1.39 log units) below the measured one; measured number above the stated range.
By their numbers in this assay, from the lowest: compound 1; then compound 2; then compound 3.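

In this assay, isopropyl on this aromatic carbon gives a 5.0-fold higher number from compound 2 to compound 3 (0.69 log units; beyond the scatter), and in place of methyl it gives a 21-fold higher number from compound 1 to compound 3 (1.31 log units; beyond the scatter) within the same series. Along hydrogen, methyl and isopropyl, the number therefore does not move in one direction with the alkyl group: methyl lowers it from the hydrogen compound, whereas isopropyl raises it. Nothing available accounts for this reversal. From the compounds shown here alone, it remains open where between methyl and isopropyl the change sets in, which an ethyl group could show. Going by these compounds, how a methoxy group or an amine on this carbon would read also remains open.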